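(Trifluoromethyl)sulfanyl in Place of Isopropoxy on a Benzyl Group

This account rests on a few compounds, and the source may have more. Where it says the series, first, only, none or still open, it means among the compounds named here.

The account follows three measured compounds and a fourth that is yet to be measured. Compound 1 `Cc1ccc2[nH]c(=O)c(CN(Cc3ccc(F)cc3)Cc3cccc4ccccc34)cc2c1` was tested in a toxicity assay on MDCK cells (Canis lupus familiaris) for cytotoxicity, read by crystal violet staining, with a stated time of 48 h; on this read-out lower numbers stand for higher toxicity in this test and higher numbers for lower toxicity in this test. In this assay compound 1 gives only a limit, > 5000 nM. Compound 2 `CCc1ccc2[nH]c(=O)c(CN(CCCO)Cc3ccc(C(C)(C)C)cc3)cc2c1` likewise gives only a limit in this assay, > 10000 nM. Compound 3 `Cc1ccc2[nH]c(=O)c(CN(Cc3ccc(OC(C)C)cc3)Cc3ccc(C(C)(C)C)cc3)cc2c1` stands at a limit as well: in this assay compound 3 gives > 5000 nM. None of the three results is a number; they sit at two limits, the limit of > 5000 nM in this assay, at which 2 of the 3 values shown sit, and (the limit of > 10000 nM in this assay, at which 1 of the 3 values shown sits). Among the compounds with values here, with every result a limit, no step between the measured compounds can be sized and no order among them can be read.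

Compound 4 `Cc1ccc2[nH]c(=O)c(CN(Cc3ccc(SC(F)(F)F)cc3)Cc3ccc(C(C)(C)C)cc3)cc2c1` differs from compound 3 in one place: (trifluoromethyl)sulfanyl in place of isopropoxy on an aromatic carbon. Within the data shown here, with no measured step on record, the expectation for this assay is a step of no size beyond the scatter, in neither direction. The estimated step that the limit leaves unreadable from compound 3 to compound 4 is accordingly expected to be small. Compound 4 is estimated to give 7000 nM in this assay, with a range from 3000 nM to 20000 nM, and most likely only a limit once more.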

Compound 4, half-maximal cytotoxic concentration: > 5000 nM
Compound 4: no number, only a limit (the forecaster's own chance of this, stated with the estimate: 85%); the middle value lies beyond the limit too.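

In this assay compound 3 and compound 4 both give only a limit, so no step between them can be read; they stand at the same limit: the limit of > 5000 nM in this assay, at which 3 of the 4 values shown sit.

The compounds shown leave open what number any of them would give in this assay, and whether (trifluoromethyl)sulfanyl in place of isopropoxy shifts that number at all.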